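Bromo to iodo on the shared core of compound 2

The source may hold more compounds than are shown below. What is called first, only, known or untested is meant among the compounds shown, and "the series" means these compounds.

Measured so far:
compound 1 `CNCc1ccccc1Sc1ccc(I)cc1CO` — 12.8 nM
compound 2 `CNCc1ccccc1Sc1ccc(Br)cc1N` — 107 nM

Of the compounds shown here, two have been measured in an assay for binding affinity to Norepinephrine transporter (Rattus norvegicus); a higher number here means a weaker inhibitor, a lower number a stronger inhibitor. Compound 1 gives 12.8 nM. Compound 2 gives 107 nM, the higher of the two numbers; the gap between them lies beyond the usual scatter, so compound 2 is the weaker inhibitor of the pair. Compound 1 and compound 2 differ in two places at once, so the contribution of either change cannot be read from these two values.

Compound 3 `CNCc1ccccc1Sc1ccc(I)cc1N` has not yet been measured. It arises from compound 2 by a single change: iodo in place of bromo on an aromatic carbon. Among the compounds with values here, no measured pair shows this exact change, so the step is judged from its small size alone. The expectation is a small step downward, within or just beyond the scatter, from compound 2 to compound 3, a 1.5-fold lower number from compound 2 to compound 3 (0.18 log units; within the scatter). For compound 3 the estimated value in this assay is 70 nM, with a range from 25 nM to 200 nM.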

Compound 3, inhibition constant: 714 nM
The estimate for compound 3 lay 10-fold (1.01 log units) below the measured number; measured number outside the range, above it.
By their numbers in this assay, from the lowest: compound 1; then compound 2; then compound 3.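

In this assay, the exchange of one halogen for another at this position is not a neutral swap: iodo in place of bromo, meta to an amino group, gives a 6.7-fold higher number from compound 2 to compound 3 (0.82 log units; beyond the scatter). With iodo held constant, amino in place of hydroxymethyl gives a 56-fold higher number from compound 1 to compound 3 (1.75 log units; beyond the scatter), a step labelled large where the halogen step is modest, so the choice between these two groups matters strongly on this core. Nothing available explains either step.

Within the data shown here, it remains open whether iodo and bromo would differ in the same direction on a core carrying hydroxymethyl rather than amino, since this halogen step is seen only with amino present. On these data alone, how a chloro or a methyl group would compare at the same aromatic carbon also remains unknown.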